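The compounds below may be only part of what the source reports. "The series", "measured", "known", "first", "only" and "open" are said of these compounds alone.

In a functional assay on HCT-15 cells (Homo sapiens) for cytotoxicity (a lower number here means a stronger inhibitor, a higher number a weaker inhibitor), compound 1 `Cc1ccc2c(N3CCN(C)CC3)nc(-c3ccc(Cl)cc3)cc2c1` gives 6030 nM and compound 2 `Cc1ccc(-c2cc3cc(C)ccc3c(N3CCN(C)CC3)n2)cc1` gives 8320 nM while compound 3 `CN1CCN(c2nc(-c3ccc(Cl)cc3)cc3c(N(C)C)cccc23)CC1` gives 7980 nM in the same range. All three lie within the scatter of one another, so compound 3 holds no separate place among them. Compound 4 `COc1ccc(-c2cc3c(N(C)C)cccc3c(N3CCN(C)CC3)n2)cc1` follows from compound 3 with methoxy in place of chloro on an aromatic carbon as the change: methoxy in place of chloro on an aromatic carbon, para to a large group. For the measured compounds named here, the one measured step that bears on it is a 1.4-fold higher number from compound 1 to compound 2 (0.14 log units; within the scatter) and it also replaces chloro on an aromatic carbon, though the entering group there is methyl and the core differs. Going by the values given here, with only that step as a guide, no step beyond the scatter is expected in this assay for this change. The expected step is a 1.1-fold lower number from compound 3 to compound 4 (0.03 log units; within the scatter) and it remains an estimate. The estimated value for compound 4 is 7500 nM with an expected range of 3500 nM to 16000 nM for repeat measurements.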

Compound 4, half-maximal inhibitory concentration: 6170 nM
Compound 4: the middle estimate sits 1.2-fold (0.08 log units) above what was measured; the range from low to high includes it.
By their numbers in this assay, from the lowest: compounds 1, 4, 3 and 2 (each within the scatter of the next).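

In this assay the change from 4-chlorophenyl to 4-methoxyphenyl gives a 1.3-fold lower number from compound 3 to compound 4 (0.11 log units; within the scatter). On the core of compound 3, this position therefore takes methoxy, with its hydrogen-bond acceptor, in place of chloro without a step beyond the scatter, whereas the earlier step covered only methyl on a different core. No supporting measurement is available to explain this reading. From the compounds shown here alone, whether an amine or a carboxylic acid at this position would move the number beyond the scatter stays open. So does whether methoxy reads the same on the core of compound 1.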